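A Chlorine Moved to Another Spot on the Benzyl Ring

This account rests on a few compounds, and the source may have more. Where it says the series, first, only, none or still open, it means among the compounds named here.

Within the data shown here, compound 1 `COc1cccc(OC)c1OCCNCCOc1ccccc1OCc1ccccc1` was tested in a functional assay on PC-3 cells (Homo sapiens) for cytotoxicity, read by sulforhodamine B assay (on this read-out higher numbers stand for lower toxicity in this test and lower numbers for higher toxicity in this test), and gives 193000 nM, the higher of the two numbers measured so far. Among the measured compounds shown here, its only measured neighbour is compound 2 `COc1cccc(OC)c1OCCNCCOc1ccccc1OCc1ccccc1Cl`, which carries chloro in place of hydrogen on an aromatic carbon and in this assay gives 58900 nM. The step of a 3.3-fold lower number from compound 1 to compound 2 (0.52 log units; beyond the scatter) lies beyond the scatter. The unmeasured compound 3 `COc1cccc(OC)c1OCCNCCOc1ccccc1OCc1cccc(Cl)c1` differs from compound 1 by chloro in place of hydrogen on an aromatic carbon, meta to a large group; read one bond further out, benzyloxy becomes (3-chlorobenzyl)oxy. For the measured compounds named here, only the step from compound 1 to compound 2 bears on this change, since it also puts chloro on that ring, so a modest drop in this assay is expected, though with wide uncertainty because a single step of a 3.3-fold lower number from compound 1 to compound 2 (0.52 log units; beyond the scatter) is the whole basis. Compound 3 is therefore expected to give 80000 nM, between 30000 nM and 200000 nM, an estimated step of a 2.4-fold lower number from compound 1 to compound 3 (0.38 log units; beyond the scatter).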

Compound 3, concentration lethal to 50% of the cells: 58900 nM
For compound 3 the middle estimate is 1.4-fold (0.13 log units) above the measured one; the measured number falls inside the stated range.
By their numbers in this assay, from the lowest: compounds 2 and 3 (each within the scatter of the next); then compound 1.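

The change to 3-chlorobenzyl gives a 3.3-fold lower number from compound 1 to compound 3 (0.52 log units; beyond the scatter) in this assay, so the lower number first seen with compound 2 also appears with chloro at this second place, meaning higher toxicity in this test. Moving the chloro gives no change at the digits printed from compound 2 to compound 3 (within the scatter), so these two compounds cannot be told apart in this test, and the step from the parent benzyl compound holds for both 2-chlorobenzyl and 3-chlorobenzyl. Nothing available here accounts for this result.

The compounds shown leave open whether the step belongs to chloro itself or would also appear with another group at this place, such as fluoro, methoxy or trifluoromethyl. They also leave open what 4-chlorobenzyl would give in this assay, and whether a second chloro on the same ring would lower the number further.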